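A few compounds are considered here, and "the series" means these few. Any claim that something is new, unique, unknown or untested is made for them only; others in the source may bear on it.

Compound 1 `COc1ccc(-n2c(SCC(=O)c3ccccc3)nnc2-c2cc(OC)c(OC)c(OC)c2)cc1` was tested in a functional assay on HCT-116 cells (Homo sapiens) for inhibition, read by MTT assay, with a stated time of 48 h; a lower number here means a stronger inhibitor, a higher number a weaker inhibitor. For compound 1 the result is only a limit of the assay, > 60000 nM. Compound 2 `COc1ccc(C(=O)CSc2nnc(-c3cc(OC)c(OC)c(OC)c3)n2-c2ccc(OC)cc2)cc1` differs from compound 1 by methoxy in place of hydrogen on an aromatic carbon. For compound 2 the result is again a limit, > 60000 nM. The step that the two limits leave unreadable from compound 1 to compound 2 thus cannot be sized, since both values sit at the limit of > 60000 nM in this assay, at which 2 of the 3 values shown sit. Compound 3 `COc1cc(-c2nnc(SCc3ccccc3)n2-c2ccc(N(C)C)cc2)cc(OC)c1OC` has a core whose difference from the core of compound 1 is not broken down here; in this assay compound 3 gives 54000 nM. Compound 4 `COc1ccc(CSc2nnc(-c3cc(OC)c(OC)c(OC)c3)n2-c2ccc(N(C)C)cc2)cc1` differs from compound 3 by methoxy in place of hydrogen on an aromatic carbon, the same change as that from compound 1 to compound 2. Compound 4 is expected to move by only a 1.1-fold higher number from compound 3 to compound 4 (0.05 log units; within the scatter), since the step that the two limits leave unreadable from compound 1 to compound 2 gives no readable size. Compound 4 is estimated at 60000 nM, between 25000 nM and 150000 nM.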

Compound 4, half-maximal inhibitory concentration: 1150 nM
Estimate against measurement, compound 4: 52-fold (1.72 log units) above; measured number below the stated range.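

In this assay, methoxy in place of hydrogen on an aromatic carbon gives a 47-fold lower number from compound 3 to compound 4 (1.67 log units; beyond the scatter), a large step on the core of compound 3. The same change on the core of compound 1 cannot be read, since compound 1 and compound 2 both stand at a limit of the assay: the limit of > 60000 nM in this assay, at which 2 of the 4 values shown sit. The series therefore shows that this change can matter greatly on one core, but it does not show whether the step carries over to the other, and it rests on a single readable pair.

The compounds shown leave open whether a hydroxyl, an ethoxy or a chlorine in the same place would match the methoxy of compound 4. They also leave open whether a longer chain on the sulfur would keep the step.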